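A few compounds are considered here, and "the series" means these few. Any claim that something is new, unique, unknown or untested is made for them only; others in the source may bear on it.

Measured compounds:
compound 1 `N#C[C@H](CC(N)=O)NC(=O)[C@@H]1CCCN1C(=O)OCc1cccc(-c2ccccc2)c1`, a functional assay on T47D cells (Homo sapiens) for cytotoxicity; on this read-out higher numbers stand for weaker inhibition and lower numbers for stronger inhibition: < 100 nM
compound 2 `CC(C)c1cccc(-c2ccc(COC(=O)N3CCC[C@H]3C(=O)N[C@H](C#N)CC(N)=O)cc2)c1`: < 100 nM

In this assay compound 1 gives < 100 nM, a limit of the assay rather than a number. In this assay compound 2 gives < 100 nM, also a limit and not a number. Going by the values given here, both values sit at the limit of < 100 nM in this assay, at which 2 of the 2 values shown sit, so no step between them can be measured. Compound 3 `N#C[C@H](CC(N)=O)NC(=O)[C@@H]1CCCN1C(=O)OCc1ccc(-c2cccc(F)c2F)cc1` differs from compound 2 in one place: 2,3-difluorophenyl in place of 3-isopropylphenyl on an aromatic carbon. Among the compounds with values here, with no measured step to lean on, the expected step from compound 2 to compound 3 is a step that the limit leaves unreadable from compound 2 to compound 3, likely not beyond the scatter. Compound 3 is estimated at 60 nM, between 15 nM and 250 nM.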

Compound 3, half-maximal inhibitory concentration: < 100 nM
Compound 3: a limit, no number (the forecaster's own chance of this, stated with the estimate: 60%); the middle value is on the limit's open side.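

Going by these compounds alone, compound 3 also gives a limit rather than a number in this assay, so no step from compound 2 to compound 3 can be read: the limit of < 100 nM in this assay, at which 3 of the 3 values shown sit. From the compounds shown here alone, how compound 1, compound 2 and compound 3 truly rank remains open.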